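The source may report more compounds than this note shows. Statements on the series, on what has been measured and on what is new or still open speak of the compounds shown alone.

Measured so far, all in a functional assay on HepG2 cells (Homo sapiens) for inhibition, read by MTT assay, with a stated time of 48 h; a lower number here means a stronger inhibitor, a higher number a weaker inhibitor: compound 1 `Brc1ccccc1CSc1nnc(-c2ccncc2)n1-c1ccccc1` with 17100 nM; compound 2 `Clc1cccc(CSc2nnc(-c3ccncc3)n2-c2ccccc2)c1` with 11200 nM; compound 3 `Clc1ccc(CSc2nnc(-c3ccncc3)n2-c2ccccc2)cc1` with 16900 nM.

Compound 2 stands within the scatter of both others: the step of a 1.5-fold lower number from compound 1 to compound 2 (0.18 log units; within the scatter) and the step of a 1.5-fold higher number from compound 2 to compound 3 (0.18 log units; within the scatter) are both small, as is a 1.0-fold lower number from compound 1 to compound 3 (0.01 log units; within the scatter). Compound 4 `O=[N+]([O-])c1cccc(CSc2nnc(-c3ccncc3)n2-c2ccccc2)c1` differs from compound 2 by nitro in place of chloro on an aromatic carbon. For the measured compounds named here, no measured step exchanges a chloro for a nitro; the steps on hand only swap one halogenated phenyl for another and all stay within the scatter, so they give neither a size nor a direction for this change. The step of a 1.1-fold higher number from compound 2 to compound 4 (0.03 log units; within the scatter) is therefore expected to stay within the scatter. For compound 4 the expected value is 12000 nM, with a range from 5000 nM to 30000 nM.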

Compound 4, half-maximal inhibitory concentration: 22000 nM
For compound 4 the middle estimate is 1.8-fold (0.26 log units) below the measured one; the range from low to high includes it.
By their numbers in this assay, from the lowest: compounds 2, 3, 1 and 4 (each within the scatter of the next).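

In this assay, the exchange of nitro for chloro on this aromatic carbon can now be read directly, and three heavy atoms in place of one leave the number within the scatter (a 2.0-fold higher number from compound 2 to compound 4 (0.29 log units; within the scatter)). The 3-nitrophenyl group also stays within the scatter of the other two aryl groups (a 1.3-fold higher number from compound 3 to compound 4 (0.11 log units; within the scatter); a 1.3-fold higher number from compound 1 to compound 4 (0.11 log units; within the scatter)). No measured evidence bears on these steps. On these data alone, whether an amine or a carboxylic acid on this aromatic carbon would also stay within the scatter remains open. So does the effect of a longer chain in place of the saturated chain carbon bound to the sulfur.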